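From thiophen-2-yl to 3,5-dimethylphenyl on a carbonyl carbon

The source may report more compounds than this note shows. Statements on the series, on what has been measured and on what is new or still open speak of the compounds shown alone.

In a functional assay on U2OS cells (Homo sapiens) for antiproliferative activity, read by MTT assay, with a stated time of 72 h (a lower number here means a stronger inhibitor, a higher number a weaker inhibitor), compound 1 `Cc1cc(C)cc(C(=O)Nc2nc3ccc(NC(=O)CSc4ccc(Cl)cc4)cc3s2)c1` gives > 100000 nM as a limit of the assay and not a number. For the measured compounds named here, compound 2 `O=C(CSc1cccc(O)c1)Nc1ccc2nc(NC(=O)c3cccs3)sc2c1` gives 63000 nM as the only actual number so far, which leaves it without a measured neighbour for comparison. Compound 3 `Cc1cc(C)cc(C(=O)Nc2nc3ccc(NC(=O)CSc4cccc(O)c4)cc3s2)c1` awaits measurement and carries 3,5-dimethylphenyl in place of thiophen-2-yl on a carbonyl carbon as its difference from compound 2. Going by the values given here, no measured step bears on this change, so the expectation rests on compound 2 alone. The expected step of a 1.2-fold higher number from compound 2 to compound 3 (0.08 log units; within the scatter) is small, leaning toward weaker inhibition and staying within the usual scatter of this assay as a read-out. Compound 3 is estimated at 75000 nM with 35000 nM to 100000 nM as its expected range.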

Compound 3, half-maximal inhibitory concentration: 2820 nM
The estimate for compound 3 lay 27-fold (1.42 log units) above the measured number; measured number outside the range, below it.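

In this assay the group on the carbonyl carbon proves to matter: 3,5-dimethylphenyl in place of thiophen-2-yl gives a 22-fold lower number from compound 2 to compound 3 (1.35 log units; beyond the scatter) and so moves the value well beyond the scatter. The group on the sulfur matters too, since 3-hydroxyphenyl in place of 4-chlorophenyl gives an at least 35-fold lower number from compound 1 to compound 3 (1.54 log units; beyond the scatter) as a step that can only be read as a minimum. The value of compound 1 is a limit of the assay and not a number: the limit of > 100000 nM in this assay, at which 1 of the 3 values shown sits.

As far as these compounds go, what a plain phenyl or a 3-methylphenyl would give on that carbonyl carbon remains open, as does a 3-aminophenyl on the sulfur.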